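This account rests on a few compounds, and the source may have more. Where it says the series, first, only, none or still open, it means among the compounds named here.

Measured in a functional assay on U-251 cells (Homo sapiens) for antiproliferative activity, read by MTT assay, with a stated time of 24 h; on this read-out higher numbers stand for weaker inhibition and lower numbers for stronger inhibition:
- compound 1 `COc1cc(OC)c(-c2coc3cc(OCc4ccccc4F)ccc3c2=O)cc1OC`: 2890 nM
- compound 2 `COc1cc(OC)c(-c2coc3cc(OCc4ccc(Br)cc4)ccc3c2=O)cc1OC`: 10000 nM
- compound 3 `COc1cc(OC)c(-c2coc3cc(OCc4ccc(C#N)cc4)ccc3c2=O)cc1OC`: 6180 nM

Compound 3 cannot be told apart from compound 2, with a 1.6-fold lower number from compound 2 to compound 3 (0.21 log units; within the scatter). It stands clear of compound 1, with a 2.1-fold higher number from compound 1 to compound 3 (0.33 log units; beyond the scatter), while compound 2 shows a 3.5-fold higher number from compound 1 to compound 2 (0.54 log units; beyond the scatter).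

Compound 4 `COc1cc(OC)c(-c2coc3cc(OCc4ccc(Cl)cc4)ccc3c2=O)cc1OC` carries chloro in place of cyano on an aromatic carbon, para to a large group (chloro in place of cyano on an aromatic carbon). The closest evidence is the exchange of bromo and cyano at that same place, which stayed within the scatter. The larger steps from compound 1 also changed the place on the ring, so they bear less directly. No step beyond the scatter is therefore expected in this assay. The estimated change is a 1.1-fold higher number from compound 3 to compound 4 (0.05 log units; within the scatter). Compound 4 is expected at about 7000 nM, with an estimated range of 3500 nM to 14000 nM.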

Compound 4, half-maximal inhibitory concentration: 470 nM
Compound 4: the middle estimate sits 15-fold (1.17 log units) above what was measured; the measured number lies below the stated range.
By their numbers in this assay, from the lowest: compound 4; then compound 1; then compounds 3 and 2 (each within the scatter of the next).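

In this assay, the bromo and cyano exchange had suggested that this aromatic carbon tolerates change, but chloro gives a 13-fold lower number from compound 3 to compound 4 (1.12 log units; beyond the scatter) and a 21-fold lower number from compound 2 to compound 4 (1.33 log units; beyond the scatter), so the outcome here depends strongly on the group and the two halogens do not behave alike. Going by these compounds alone, the change from 2-fluorophenyl to 4-chlorophenyl also gives a 6.1-fold lower number from compound 1 to compound 4 (0.79 log units; beyond the scatter), a step beyond the scatter, unlike the earlier steps away from the 2-fluorophenyl group, which raised the number. Nothing available explains this difference. From the compounds shown here alone, whether a methyl or an amine on this aromatic carbon would match chloro remains open.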